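A few compounds are considered here, and "the series" means these few. Any claim that something is new, unique, unknown or untested is made for them only; others in the source may bear on it.

Measured compounds and their numbers in an assay on membranes from lung for binding affinity to cysteinyl leukotriene receptor 1 (Cavia porcellus); a higher number here means a weaker inhibitor, a lower number a stronger inhibitor:
- compound 1, `CCNC(=O)c1ccccc1CCC(SCC(CC)C(=O)O)c1cccc(OCc2ccc3ccc(Cl)cc3n2)c1`: 0.45 nM
- compound 2, `O=C(O)CCSC(CCc1ccccc1-c1nc[nH]n1)c1cccc(OCc2ccc3ccc(Cl)cc3n2)c1`: 0.36 nM
- compound 3, `CCC(CSC(CCc1ccccc1C#N)c1cccc(CCc2ccc3ccc(Cl)cc3n2)c1)C(=O)O`: 1 nM

Compound 2 gives the lowest of the three numbers in this assay. Its nearest neighbour is compound 1, whose number is within the scatter of it, so the two are not separated. Among the compounds with values here, compound 3 sits further off, beyond the scatter, and the three compounds differ from one another in more than one place, so no single step between measured compounds is available.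

Compound 4, `CC(CCC(SCCC(=O)O)c1cccc(OCc2ccc3ccc(Cl)cc3n2)c1)CC(=O)N(C)C`, has not been measured. Against compound 2 the change is 1-((dimethylcarbamoyl)methyl)ethyl in place of 2-(1H-1,2,4-triazol-3-yl)phenyl on a saturated chain carbon, three bonds along the chain from an aromatic carbon and a sulfur. Within the data shown here, no measured pair shows this change or a comparable one; the nearest point of reference is that compound 1 carries an amide on an aromatic ring in the same region and gives 0.45 nM, while compound 4 has no ring there at all.

With nothing to anchor the step, the expectation is a moderate move upwards, beyond the scatter, since all three measured compounds keep an aromatic ring at that place and compound 4 does not. Compound 4 is estimated at 5 nM, within 1 nM to 30 nM, which means an expected step of a 14-fold higher number from compound 2 to compound 4 (1.14 log units; beyond the scatter).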

Compound 4, half-maximal inhibitory concentration: 8.6 nM
Compound 4: middle estimate off by 1.7-fold (0.24 log units), on the low side; low and high end bracket the measured number.
By their numbers in this assay, from the lowest: compounds 2 and 1 (each within the scatter of the next); then compound 3; then compound 4.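

At the saturated chain carbon, three bonds along the chain from an aromatic carbon and a sulfur, 1-((dimethylcarbamoyl)methyl)ethyl in place of 2-(1H-1,2,4-triazol-3-yl)phenyl gives in this assay a large step, a 24-fold higher number from compound 2 to compound 4 (1.38 log units; beyond the scatter). Within the data shown here, this is the only measured step at this place, and it shows that an aromatic ring there is not strictly required for a measurable number, since compound 4, with no ring in the entering group, still gives 8.6 nM, though the change costs a clear loss against the triazolylphenyl group. No data are available that explain the size of this step.

Both rings and the triazole leave in the same step while the dimethylcarbamoyl group enters, so the compounds shown leave open how much of the step belongs to the phenyl ring, to the triazole and to the amide. A plain phenyl or a cyclohexyl at this place, or a 2-(dimethylcarbamoyl)phenyl on the otherwise unchanged compound 2, would separate these contributions.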